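The compounds below may be only part of what the source reports. "The series", "measured", "known", "first", "only" and "open" are said of these compounds alone.

Compound 2 `CCc1cc(C(C)=O)c(O)cc1OCCCCCn1cncn1` has the lower number of the two measured compounds: in an assay on isolated protein for binding affinity to leukotriene B4 receptor 1 (Homo sapiens), tested at 1 uM (a lower number here means less inhibition, a higher number more inhibition at the concentration tested (going by the name of the read-out)), compound 2 gives 30%, while compound 1 `CCc1cc(C(C)=O)c(O)cc1OCCCCCC(C)(C)c1nnn(C)n1` gives 66%. Within the data shown here, the single measured step, a number 36 percentage points lower from compound 1 to compound 2 (beyond the scatter), runs between these two. Compound 3 `CCc1cc(C(C)=O)c(O)cc1OCCCCCCC(=O)Nc1nn[nH]n1` has not yet been measured. Its change from compound 2 is ((2H-tetrazol-5-yl)carbamoyl)methyl in place of 1H-1,2,4-triazol-1-yl on a saturated chain carbon, five bonds along the chain from an oxygen on an aromatic ring. This step bears on the only measured one, because in a number 36 percentage points lower from compound 1 to compound 2 (beyond the scatter) a group carrying a tetrazole ring was swapped for a triazole and the reading fell sharply; compound 3 puts a tetrazole-bearing group back, though a different one, with an amide link. A rise beyond the scatter is therefore expected for compound 3, but smaller than the full step back to compound 1, since the new group differs in shape and in its donors and acceptors. For compound 3 the estimate is 50%, with a range from 25% to 75%, meaning an expected step of a number 20 percentage points higher from compound 2 to compound 3 (beyond the scatter).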

Compound 3, a percentage reported as inhibition, at one concentration (the size of the read-out at that concentration, not a potency): 83%
The estimate for compound 3 lay 33 percentage points below the measured number, outside the stated range (above it).
By their numbers in this assay, from the lowest: compound 2; then compound 1; then compound 3.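

In this assay, a number 53 percentage points higher from compound 2 to compound 3 (beyond the scatter) when ((2H-tetrazol-5-yl)carbamoyl)methyl, with 9 heavy atoms, replaces 1H-1,2,4-triazol-1-yl, with 5, so this chain position accepts a larger group, and one with an amide link, without any loss of the reading. The same group also goes past the tetrazole-bearing group of compound 1, giving a number 17 percentage points higher from compound 1 to compound 3 (beyond the scatter), which shows that the 1-methyl-1-(2-methyl-2H-tetrazol-5-yl)ethyl group is not the best of the groups shown at this place. No measurement here explains either rise.

The compounds shown leave open whether the tetrazole ring or the amide link carries the gain, a question that a carboxylic acid at the chain end or a simple amide without the ring could help to settle. They also leave open how a longer or shorter chain would change the reading, and how potency compares, as each number comes from a single concentration.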